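Removing the five-oxygen chain from the core of compound 1

The compounds below may be only part of what the source reports. "The series", "measured", "known", "first", "only" and "open" are said of these compounds alone.

Compound 1 `COc1ccnc(CNc2ccc3c(c2)nc(C)n3C[C@@H](O)[C@H]2O[C@H](O)[C@@H](O)[C@H]2O)c1OC` was tested in a functional assay on the whole organism (stomach, strain Swiss albino) for inhibition, with Mus musculus as the target, with a stated time of 3 days, at a dose of 7.2 mg/kg by the oral route (on this read-out lower numbers stand for a weaker effect and higher numbers for a stronger effect at the one dose given), where compound 1 gives 73%. Among the three measured compounds it stands second of three, though each neighbour lies within the scatter: compound 2 `COc1ccnc(CNc2ccc3c(c2)nc(C)n3C[C@@H](O)[C@H]2O[C@H](O)[C@@H](O)[C@H]2O)c1C` gives 66.6%, and compound 3 `COc1c(C)cnc(CNc2ccc3c(c2)nc(C)n3C[C@@H](O)[C@H]2O[C@H](O)[C@@H](O)[C@H]2O)c1C` gives 76.2%. The steps between them are small: a number 6.4 percentage points lower from compound 1 to compound 2 (within the scatter), a number 3.2 percentage points higher from compound 1 to compound 3 (within the scatter), and a number 9.6 percentage points higher from compound 2 to compound 3 (within the scatter). All three steps alter the substituents on the pyridin-2-yl group and leave the rest of the molecule untouched.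

Compound 4 `COc1ccnc(CNc2ccc3[nH]c(C)nc3c2)c1OC` differs from compound 1 in another place: a hydrogen atom in place of a group of 11 heavy atoms (6 carbon, 5 oxygen; one five-membered non-aromatic ring with 1 hetero atom), on an aromatic nitrogen. Within the data shown here, none of the measured steps touches this aromatic nitrogen, so no measured step bears on the change, and nothing shows whether the group of 11 heavy atoms is needed for the effect. The reading for compound 4 in this assay is therefore estimated from compound 1 alone and is expected near the value of compound 1, with the step of a number 8 percentage points lower from compound 1 to compound 4 (within the scatter) carrying a wide uncertainty. The estimate for compound 4 is 65%, expected to fall between 35% and 90%.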

Compound 4, a percentage reported as inhibition, in the whole organism at one dose (the size of the read-out at that dose, not a potency): 46.8%
Estimate against measurement, compound 4: 18.2 percentage points above; measured number inside the range.
By their numbers in this assay, from the lowest: compound 4; then compounds 2, 1 and 3 (each within the scatter of the next).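

Among these compounds, replacing the group of 11 heavy atoms with a hydrogen atom on the aromatic nitrogen gives, in this assay, a number 26.2 percentage points lower from compound 1 to compound 4 (beyond the scatter) and is the only step that lies beyond the scatter, whereas the three earlier steps, all on the pyridin-2-yl group, stayed within it. The group on this nitrogen therefore contributes to the read-out at this dose, yet it is not required for all of it, since compound 4 still gives 46.8% without the group. No measurement at hand accounts for the lower number, so the result says what happens at this position but not how it comes about.

The compounds shown leave open whether the whole group with its five-membered non-aromatic ring is needed or only a part of it, as a methyl group, a 2-hydroxyethyl chain or an acetic acid side chain on the same nitrogen would begin to tell. They also leave open whether the substituents on the pyridin-2-yl group would matter more or less once the group of 11 heavy atoms has gone.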